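The source may hold more compounds than are shown below. What is called first, only, known or untested is meant among the compounds shown, and "the series" means these compounds.

Notes on the series.

Going by the values given here, the three measured members share one core. Compound 1 `CC(C)N(c1nc(Cl)nc(N[C@@H](C)c2ccccc2)n1)C(C)C` carries a diisopropylamino group; compound 2 `C[C@H](Nc1nc(Cl)nc(NC(C)(C)C)n1)c1ccccc1` and compound 3 `C[C@@H](Nc1nc(Cl)nc(NC(C)(C)C)n1)c1ccccc1` carry a (tert-butyl)amino group instead and differ from each other only in configuration as drawn, the counted difference being (the two compounds have the same atoms and bonds and differ only in configuration as drawn: 1 of 1 stereo elements differ; a stereocentre at a saturated chain carbon is drawn S in compound 2 and R in compound 3). In an ADME assay on the whole organism for inhibition, with Oryza sativa as the target, with a stated time of 4 days (on this read-out lower numbers stand for stronger inhibition and higher numbers for weaker inhibition), compound 1 gives 372 nM, compound 2 gives 3310 nM and compound 3 gives 9330 nM. Compound 3 therefore stands highest of the three. The step of a 2.8-fold higher number from compound 2 to compound 3 (0.45 log units; beyond the scatter) is modest but beyond the scatter, and it rests on (the fact that compounds 2 and 3 differ only in the configuration as drawn).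

The replacement diisopropylamino in place of (tert-butyl)amino on an aromatic carbon produced the step of an 8.9-fold lower number from compound 2 to compound 1 (0.95 log units; beyond the scatter), also beyond the scatter.

Compound 4 `CC(C)N(c1nc(Cl)nc(N[C@H](C)c2ccccc2)n1)C(C)C` is not yet measured in this assay. Among the compounds with values here, it differs from compound 3 by diisopropylamino in place of (tert-butyl)amino on an aromatic carbon, which is the same change as the one from compound 2 to compound 1, at the same place on the core, applied this time to the configuration drawn in compound 3. Within the data shown here, the step from compound 3 to compound 4 is expected to be about as large as the measured one, namely an 8.5-fold lower number from compound 3 to compound 4 (0.93 log units; beyond the scatter), since the only precedent for this change is the step of an 8.9-fold lower number from compound 2 to compound 1 (0.95 log units; beyond the scatter). Because compound 3 gives 9330 nM, compound 4 is estimated at 1100 nM in this assay, with a plausible range from 500 nM to 2600 nM.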

Compound 4, half-maximal inhibitory concentration: 1620 nM
The estimate for compound 4 lay 1.5-fold (0.17 log units) below the measured number, within the range that was stated.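

In this assay, diisopropylamino in place of (tert-butyl)amino on the other configuration gives a 5.8-fold lower number from compound 3 to compound 4 (0.76 log units; beyond the scatter), and the change carries over at a size that matches the earlier step: the same change on two cores in this assay, an 8.9-fold lower number (0.95 log units; beyond the scatter) from compound 2 to compound 1 and a 5.8-fold lower number (0.76 log units; beyond the scatter) from compound 3 to compound 4, 1.5-fold (0.19 log units) apart, within the scatter of two such steps. The gap in configuration also persists once diisopropylamino is present, with a 4.4-fold higher number from compound 1 to compound 4 (0.64 log units; beyond the scatter), in the same direction as a 2.8-fold higher number from compound 2 to compound 3 (0.45 log units; beyond the scatter): the fact that compounds 1 and 4 differ only in the configuration as drawn. This shows transfer of the change across two mirror-drawn forms of one shared core, with a single step on each, and it shows neither transfer to a core altered in any other place nor why the number falls.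

As far as these compounds go, all four compounds keep the chloro group, so whether a methoxy group in its place would preserve either the amine step or the gap in configuration stays open. Also open, from the compounds shown here alone, is whether the lower numbers follow diisopropylamino alone or extend to other amines, such as dimethylamino, diethylamino or a cyclic amine like morpholine.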